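Isopropyl to hexyl across two related cores

The source may hold more compounds than are shown below. What is called first, only, known or untested is meant among the compounds shown, and "the series" means these compounds.

Measured so far:
compound 1 `Cc1ccc(S(=O)(=O)N2CC[C@@H](Br)C[C@@H]2CC(C)C)cc1`: 22000 nM
compound 2 `CCCCCCC[C@H]1C[C@H](Br)CCN1S(=O)(=O)c1ccc(C)cc1`: > 100000 nM, which is a limit of the assay, not a number
compound 3 `Cc1ccc(S(=O)(=O)N2CCC(Cl)=CC2CC(C)C)cc1`: 31000 nM

In a functional assay on SW1573 cells (Homo sapiens) for antiproliferative activity, read by sulforhodamine B assay, with a stated time of 48 h (a lower number here means a stronger inhibitor of growth, a higher number a weaker inhibitor of growth), compound 1 gives 22000 nM. Compound 3 differs from compound 1 in its core, and the difference between the two cores is not broken down here; in this assay compound 3 gives 31000 nM, a value within the scatter of compound 1. For the measured compounds named here, the one measured step is an at least 4.5-fold higher number from compound 1 to compound 2 (0.65 log units; beyond the scatter), the change being (hexyl in place of isopropyl on a saturated chain carbon bound to a saturated ring carbon). Compound 2 stops at a limit (the limit of > 100000 nM in this assay, at which 1 of the 3 values shown sits).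

Compound 4 `CCCCCCCC1C=C(Cl)CCN1S(=O)(=O)c1ccc(C)cc1` carries the same change on the core of compound 3: hexyl in place of isopropyl on a saturated chain carbon bound to a saturated ring carbon. The step from compound 3 to compound 4 in this assay is expected to be a 3.2-fold higher number from compound 3 to compound 4 (0.51 log units; beyond the scatter) because an at least 4.5-fold higher number from compound 1 to compound 2 (0.65 log units; beyond the scatter). Compound 4 is therefore expected near 100000 nM, between 40000 nM and 300000 nM, with a fair chance of only a limit.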

Compound 4, concentration for 50% growth inhibition: 49000 nM
Compound 4: middle estimate off by 2.0-fold (0.31 log units), on the high side, and the stated range covers the measured number.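

In this assay, hexyl in place of isopropyl does not carry over in size from one core to the other, with the later pair giving a 1.6-fold higher number from compound 3 to compound 4 (0.20 log units; within the scatter). The two steps differ: the same change on two cores in this assay, an at least 4.5-fold higher number (0.65 log units; beyond the scatter) from compound 1 to compound 2 and a 1.6-fold higher number (0.20 log units; within the scatter) from compound 3 to compound 4, at least 2.8-fold (0.45 log units) apart, beyond the scatter of two such steps. Compound 2 gives > 100000 nM, which is a limit of the assay, and with a single pair on each core the result does not show how the change would run on any other core.

Open, from the compounds shown here alone, is what a butyl chain, or a chain longer than hexyl, would give on either core. Also open, going by these compounds, is what a chain carrying an amine or a carboxylic acid would give at the same place.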